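Oxanylcarbonyl ester in place of the hydroxypropyl ether

The source may report more compounds than this note shows. Statements on the series, on what has been measured and on what is new or still open speak of the compounds shown alone.

Compound 3 `CC(C)=CC[C@@H](OCC(C)O)C1=CC(=O)c2c(O)ccc(O)c2C1=O` is one of two compounds with a number in a functional assay on HeLa cells (Homo sapiens) for cytotoxicity, read by MTT assay; a lower number here means a stronger inhibitor, a higher number a weaker inhibitor; in this assay compound 3 gives 24700 nM. Compound 1 `CC(C)=CC[C@@H](OC[C@H](C)O)C1=CC(=O)c2c(O)ccc(O)c2C1=O` gives 40300 nM, and the gap a 1.6-fold lower number from compound 1 to compound 3 (0.21 log units; within the scatter) is within the scatter, so the two stand level. For compound 2 `CC(C)=CC[C@@H](OC(=O)C1CCCCO1)C1=CC(=O)c2c(O)ccc(O)c2C1=O` this assay reports only a limit, > 100000 nM. The ester steps read an at least 2.4-fold higher number from compound 1 to compound 2 (0.39 log units; beyond the scatter) and an at least 4.0-fold lower number from compound 2 to compound 3 (0.60 log units; beyond the scatter).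

Compound 4 `CC(C)=CC[C@@H](OC(=O)C1CCCOC1)C1=CC(=O)c2c(O)ccc(O)c2C1=O` differs from compound 3 by (oxan-3-yl)carbonyl in place of 2-hydroxypropyl on an oxygen on a saturated carbon. This change resembles the ester steps above, which both moved the number up, so compound 4 is expected to be weaker, with a 4.0-fold higher number from compound 3 to compound 4 (0.61 log units; beyond the scatter). The estimate for compound 4 is 100000 nM, with a range from 40000 nM to 300000 nM, and a limit is likely.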

Compound 4, half-maximal inhibitory concentration: 60500 nM
Estimate against measurement, compound 4: 1.7-fold (0.22 log units) above; low and high end bracket the measured number.
By their numbers in this assay, from the lowest: compounds 3, 1 and 4 (each within the scatter of the next, the first and the last beyond it). At a limit, above all of these: compound 2.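

In this assay, an ester on this oxygen can still give a measured number: with (oxan-3-yl)carbonyl in place of 2-hydroxypropyl, the step reads a 2.4-fold higher number from compound 3 to compound 4 (0.39 log units; beyond the scatter), whereas the same change made from the other ether reads a 1.5-fold higher number from compound 1 to compound 4 (0.18 log units; within the scatter). Whether the ester change registers therefore depends on the ether used as reference, and those two ethers carry a caveat: the fact that one of compounds 1 and 3 is drawn with a defined configuration and the other without, at the place where they differ. Compound 2 gives only a limit, > 100000 nM. With that limit as its starting point, the step between the two oxanyl esters, oxan-3-yl in place of oxan-2-yl on a carbonyl carbon, reads an at least 1.6-fold lower number from compound 2 to compound 4 (0.21 log units; that floor lies within the scatter), so only a floor is known for it.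

Open, from the compounds shown here alone, is how an acetyl ester, a longer chain or an amine on this oxygen would read.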